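Tethered amine variants against calf thymus DNA

The compounds below may be only part of what the source reports. "The series", "measured", "known", "first", "only" and "open" are said of these compounds alone.

Three compounds share one core and differ only in the amine at the end of a short chain. In an assay on nucleic acid for binding affinity to Calf thymus DNA (Bos taurus) (a higher number here means a weaker inhibitor, a lower number a stronger inhibitor), compound 1 `CN(C)CCn1c2ccc3ccccc3c2c2nc3ccccc3nc21` gives 14500 nM, compound 2 `CCCN(CCC)CCn1c2ccc3ccccc3c2c2nc3ccccc3nc21` gives 15800 nM, and compound 3 `c1ccc2c(c1)ccc1c2c2nc3ccccc3nc2n1CCN1CCCCC1` gives 30900 nM. Compound 2 thus sits between the two others, and both gaps, a 1.1-fold higher number from compound 1 to compound 2 (0.04 log units; within the scatter) and a 2.0-fold higher number from compound 2 to compound 3 (0.29 log units; within the scatter), are small. Compound 4 `CC1CCCCN1CCn1c2ccc3ccccc3c2c2nc3ccccc3nc21` carries 2-methylpiperidin-1-yl in place of dipropylamino on a saturated chain carbon, two bonds along the chain from an aromatic nitrogen. The closest guide is a 2.0-fold higher number from compound 2 to compound 3 (0.29 log units; within the scatter), with a 2.1-fold higher number from compound 1 to compound 3 (0.33 log units; beyond the scatter) pointing the same way, so a small rise in this assay, or none beyond the scatter, is expected, namely a 1.8-fold higher number from compound 2 to compound 4 (0.25 log units; within the scatter). Compound 4 is therefore estimated at 28000 nM, with a likely range from 14000 nM to 56000 nM.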

Compound 4, half-maximal inhibitory concentration: 18600 nM
Compound 4: middle estimate off by 1.5-fold (0.18 log units), on the high side, and the stated range covers the measured number.
By their numbers in this assay, from the lowest: compounds 1, 2, 4 and 3 (each within the scatter of the next, the first and the last beyond it).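

In this assay, methyl in place of hydrogen on a saturated ring carbon gives a 1.7-fold lower number from compound 3 to compound 4 (0.22 log units; within the scatter) and so leaves compound 4 level with compound 3. Putting in 2-methylpiperidin-1-yl likewise gives a 1.2-fold higher number from compound 2 to compound 4 (0.07 log units; within the scatter) and a 1.3-fold higher number from compound 1 to compound 4 (0.11 log units; within the scatter) against the open-chain amines. Compound 4 thus lies within the scatter of all three others, so this ring with its methyl stands apart from none of them. Going by these compounds, whether a morpholine ring or a primary amine at the chain end, or a longer chain, would give a step beyond the scatter stays open. No measurement at hand explains why these amines read so alike.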